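Swapping 2-fluorophenyl for 4-fluorophenyl on the shared core

A few compounds are considered here, and "the series" means these few. Any claim that something is new, unique, unknown or untested is made for them only; others in the source may bear on it.

Compound 1 `Oc1nc(-c2ccccc2F)nc2ccccc12`: > 20 ug/mL
Compound 2 `Oc1nc(-c2ccc(F)cc2)nc2ccccc12`: > 20 ug/mL
Compound 3 `COc1cc2nc(-c3ccccc3F)nc(O)c2cc1OC`: < 5 ug/mL

All three results come from a functional assay on KB cells (Homo sapiens) (a lower number here means that less compound is needed, a higher number that more compound is needed for the effect), and each is a limit of the assay, not a number. Compound 3 stands alone at the limit of < 5 ug/mL in this assay, at which 1 of the 3 values shown sits. The other two stand together at the limit of > 20 ug/mL in this assay, at which 2 of the 3 values shown sit.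

Compound 4 `COc1cc2nc(-c3ccc(F)cc3)nc(O)c2cc1OC` has not been measured. It differs from compound 3 in one place, with 4-fluorophenyl in place of 2-fluorophenyl on an aromatic carbon. Compound 1 and compound 2 carry this same pair of groups, and they share one limit, so no size can be read from them. No step beyond the scatter is expected in this assay, in either direction. This expectation rests on compound 3, whose < 5 ug/mL is a limit. The expected change is a step that the limit leaves unreadable from compound 3 to compound 4. The estimate for compound 4 is 4 ug/mL, within an expected range of 1 ug/mL to 15 ug/mL.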

Compound 4, concentration for half-maximal effect: > 20 ug/mL
Compound 4 gave a limit, no number; the forecaster's own chance of this, stated with the estimate: 45%; at least 5.0-fold (0.69 log units) between middle value and limit.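

On the core of compound 3, where the fluorine sits on the phenyl ring makes a readable difference: in this assay, 4-fluorophenyl in place of 2-fluorophenyl gives an at least 4.0-fold higher number from compound 3 to compound 4 (0.60 log units; beyond the scatter). Both ends of this step are limits of the assay, so only its smallest possible size can be read. The same pair of groups on the core of compound 1 gave no readable difference.

From the compounds shown here alone, the true size of the step stays open. So does whether 3-fluorophenyl, 2-chlorophenyl or plain phenyl in this place would side with compound 3 or compound 4.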